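Nitro-to-amino swaps on two indanone-derived enone scaffolds

The source may report more compounds than this note shows. Statements on the series, on what has been measured and on what is new or still open speak of the compounds shown alone.

Compound 1, `COc1cc2c(cc1OC)C(=O)/C(=C/c1cc(C)c([N+](=O)[O-])c(C)c1)C2`, in a functional assay on Jurkat cells (Homo sapiens) for antiproliferative activity, read by MTT assay; a higher number here means a weaker inhibitor, a lower number a stronger inhibitor: 25000 nM
Compound 2, `COc1cc2c(cc1OC)C(=O)/C(=C/c1cc(C)c(N)c(C)c1)C2`, in this assay: 55 nM
Compound 3, `COc1cc2c(c([N+](=O)[O-])c1O)C/C(=C\c1cc(C)c(O)c(C)c1)C2=O`, in this assay: 9300 nM

Compound 1 and compound 2 share a core and differ in one place: amino in place of nitro on an aromatic carbon. That single change made a 450-fold lower number from compound 1 to compound 2 (2.66 log units; beyond the scatter) in this assay, the largest movement among the three measured compounds.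

Compound 3 stands between them. Its number in this assay is lower than that of compound 1 and far higher than that of compound 2, both gaps beyond the scatter. How the core of compound 3 differs from that of compound 1 is not broken down here.

Compound 4, `COc1cc2c(c(N)c1O)C/C(=C\c1cc(C)c(O)c(C)c1)C2=O`, has not yet been measured. It differs from compound 3 in one place: amino in place of nitro on an aromatic carbon. Within the data shown here, this is the same kind of change as the one from compound 1 to compound 2, but at a different place: in the earlier pair the carbon sits ortho to two methyl groups and para to a large group, whereas in compound 4 it sits on a ring that is part of a fused system of two rings, ortho to a fused ring and ortho to a hydroxy group, meta to a fused ring and meta to a methoxy group. Resting on the step from compound 1 to compound 2, a lower number is expected for compound 4, but with wide uncertainty since the surroundings differ; the expected step is a 10-fold lower number from compound 3 to compound 4 (1.01 log units; beyond the scatter). Compound 4 is estimated at 900 nM in this assay, with a range from 150 nM to 5000 nM.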

Compound 4, half-maximal inhibitory concentration: 30000 nM
Compound 4: the middle estimate sits 33-fold (1.52 log units) below what was measured, outside the stated range (above it).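

On the core of compound 3, amino in place of nitro on an aromatic carbon gave a 3.2-fold higher number from compound 3 to compound 4 (0.51 log units; beyond the scatter) in this assay, so the number rose where it had fallen steeply on the core of compound 1. The change therefore did not carry over from one core to the other in this series, in either direction or size: the same change on two cores in this assay, a 450-fold lower number (2.66 log units; beyond the scatter) from compound 1 to compound 2 and a 3.2-fold higher number (0.51 log units; beyond the scatter) from compound 3 to compound 4, 1500-fold (3.17 log units) apart, beyond the scatter of two such steps This does not show which difference between the two pairs matters, as the cores differ in more than one place and the changed carbon has different surroundings in each, being ortho to a hydroxy group in compound 4 and ortho to two methyl groups in compound 2, and two pairs cannot give a rule for any further core.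

The compounds shown leave open how this assay would respond on either core if a dimethylamino group, an acetamide or a chlorine atom stood on that aromatic carbon in place of the nitro or amino group. They also leave open whether the outcome on the core of compound 3 depends on the hydroxy group ortho to the changed carbon, which a compound with an ethoxy group in its place could help to settle.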